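The source may hold more compounds than are shown below. What is called first, only, known or untested is meant among the compounds shown, and "the series" means these compounds.

Of the compounds shown here, three have been measured in a functional assay, with a stated time of 20 min, tested at 10 uM; on this read-out higher numbers stand for a stronger effect at the one concentration tested and lower numbers for a weaker effect. Compound 1 `COc1cc(/C=C/C(=O)C2=C(/C=C/c3ccc(O)c(OC)c3)NC(=O)NC2c2ccccc2)ccc1O` gives 26.4%, and compound 2 `COc1cc(/C=C/C(=O)C2=C(/C=C/c3ccc(O)c(OC)c3)NC(=S)NC2c2ccccc2)ccc1O` gives 26.5%, two numbers within the scatter of each other. Compound 3 `COc1cc(/C=C/C(=O)C2=C(/C=C/c3ccc(O)c(OC)c3)NC(=S)NC2c2ccccc2O)ccc1O` gives 60.2%, the highest of the three numbers: its nearest neighbour is compound 2, a number well below it, and compound 1 lies a little further still. For the measured compounds named here, the single one-place step, a number 33.7 percentage points higher from compound 2 to compound 3 (beyond the scatter), shows that the hydroxy on that aromatic carbon goes with the whole of this gain.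

Compound 4 `COc1cc(/C=C/C(=O)C2=C(/C=C/c3ccc(O)c(OC)c3)NC(=S)NC2c2c(Cl)cccc2Cl)ccc1O` is not yet measured. It differs from compound 3 in one place: 2,6-dichlorophenyl in place of 2-hydroxyphenyl on a saturated ring carbon. Going by the values given here, the change removes the hydroxy whose arrival made the large step from compound 2 to compound 3, and no measured compound carries a dichlorophenyl, so the two chlorines add uncertainty. Compound 4 is therefore expected to fall back toward the level of compound 2, a step estimated as a number 28.2 percentage points lower from compound 3 to compound 4 (beyond the scatter), with compound 4 estimated at 32% in a range from 15% to 55%.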

Compound 4, a percentage reported as activity, at one concentration (the size of the read-out at that concentration, not a potency): 29%
The estimate for compound 4 lay 3 percentage points above the measured number; the range from low to high includes it.
By their numbers in this assay, from the lowest: compounds 1, 2 and 4 (each within the scatter of the next); then compound 3.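

In this assay, 2,6-dichlorophenyl in place of 2-hydroxyphenyl on the saturated ring carbon gives a number 31.2 percentage points lower from compound 3 to compound 4 (beyond the scatter), so a substituted phenyl at this position does not by itself carry the higher number. With 2,6-dichlorophenyl in place of phenyl the result is a number 2.5 percentage points higher from compound 2 to compound 4 (within the scatter), so the two chlorines cannot be told apart from the plain phenyl in this read-out, and among these compounds only the 2-hydroxyphenyl stands out. Nothing available explains why the hydroxy goes with the gain and the chlorines do not.

On these data alone, what a methoxy or an amine on that phenyl would give remains open, as does whether a single chlorine would read like the two. As far as these compounds go, it is also open whether the hydroxy brings the same gain on the core of compound 1.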